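From butyl to 3-methoxypropyl in compound 3

The source may report more compounds than this note shows. Statements on the series, on what has been measured and on what is new or still open speak of the compounds shown alone.

Measured in a physicochemical assay for lipophilicity, using the shake flask method; on this read-out higher numbers stand for higher lipophilicity and lower numbers for lower lipophilicity:
- compound 1 `C=CCO/N=C/c1c(N)ncnc1Oc1ccc(NC(=O)C2(C(=O)Nc3ccc(F)cc3)CC2)cc1F`: 3.65
- compound 2 `C#CCO/N=C/c1c(N)ncnc1Oc1ccc(NC(=O)C2(C(=O)Nc3ccc(F)cc3)CC2)cc1F`: 3.34
- compound 3 `CCCCO/N=C/c1c(N)ncnc1Oc1ccc(NC(=O)C2(C(=O)Nc3ccc(F)cc3)CC2)cc1F`: 4.2

Compound 3, at 4.2, stands highest of the three, clear of both others. Compound 4 `COCCCO/N=C/c1c(N)ncnc1Oc1ccc(NC(=O)C2(C(=O)Nc3ccc(F)cc3)CC2)cc1F` differs from it by methoxy in place of methyl on a saturated chain carbon, three bonds along the chain from an oxygen on an unsaturated carbon, which amounts to butyl to 3-methoxypropyl. The measured steps all alter this same chain: a number 0.31 log units lower from compound 1 to compound 2 (beyond the scatter), a number 0.55 log units higher from compound 1 to compound 3 (beyond the scatter) and a number 0.86 log units higher from compound 2 to compound 3 (beyond the scatter). None of them introduces methoxy, so they offer only a guide to size, and the largest is the best yardstick. A fall in this assay of similar size is expected, with the added hydrogen-bond acceptor as the basis for its direction. The expected step is a number 0.90 log units lower from compound 3 to compound 4 (beyond the scatter). Compound 4 is estimated at 3.3, with a range of 2.9 to 3.7.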

Compound 4, partition coefficient: 3.18
The estimate for compound 4 lay 0.12 log units above the measured number; the range from low to high includes it.
By their numbers in this assay, from the lowest: compounds 4 and 2 (each within the scatter of the next); then compound 1; then compound 3.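

Methoxy in place of methyl, which amounts to butyl to 3-methoxypropyl, gives the largest step at this position so far in this assay (a number 1.02 log units lower from compound 3 to compound 4 (beyond the scatter)). The chain is longer than the vinyl-bearing chain of compound 1 yet still reads lower (a number 0.47 log units lower from compound 1 to compound 4 (beyond the scatter)), while compound 4 and compound 2 remain within the scatter of each other (a number 0.16 log units lower from compound 2 to compound 4 (within the scatter)). No evidence is available to explain these steps.

From the compounds shown here alone, what an amine or a carboxylic acid in place of methyl would read in this assay remains open. So does whether a longer chain carrying methoxy would follow compound 4.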